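This account rests on a few compounds, and the source may have more. Where it says the series, first, only, none or still open, it means among the compounds named here.

Compound 1 `O=C(NNC(=O)c1ccccc1F)c1ccc(NS(=O)(=O)c2cnc(O)nc2O)cc1` gives 7610 nM. Compound 2 `O=C(NNC(=O)c1ccc(NS(=O)(=O)c2cnc(O)nc2O)cc1)c1ccc(F)cc1` reaches only a limit of the assay, > 20000 nM. Compound 3 `O=C(NNC(=O)c1ccccc1F)c1cccc(NS(=O)(=O)c2cnc(O)nc2O)c1` gives 10800 nM.

These numbers come from a functional assay on A549 cells (Homo sapiens) for antiproliferative activity, read by MTT assay, with a stated time of 24 h; on this read-out higher numbers stand for weaker inhibition and lower numbers for stronger inhibition. From compound 1 to compound 2 the change is 4-fluorophenyl in place of 2-fluorophenyl on a carbonyl carbon, and it made an at least 2.6-fold higher number from compound 1 to compound 2 (0.41 log units; beyond the scatter); the number for compound 2 is a limit, (the limit of > 20000 nM in this assay, at which 1 of the 3 values shown sits). Compound 1 and compound 3 are built from the same atoms joined differently, but the difference between their cores is not broken down here, and their two values lie within the scatter of each other. Compound 4 `O=C(NNC(=O)c1cccc(NS(=O)(=O)c2cnc(O)nc2O)c1)c1ccc(F)cc1` is compound 3 carrying the same change, (4-fluorophenyl in place of 2-fluorophenyl on a carbonyl carbon), at a place described in the same words. Set beside an at least 2.6-fold higher number from compound 1 to compound 2 (0.41 log units; beyond the scatter), the step expected is a 2.8-fold higher number from compound 3 to compound 4 (0.44 log units; beyond the scatter), which is expected to carry compound 4 past the limit (the limit of > 20000 nM in this assay, at which 1 of the 3 values shown sits). Compound 4 is therefore estimated at 30000 nM.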

Compound 4, half-maximal inhibitory concentration: > 20000 nM
Compound 4 gave a limit, no number (the forecaster's own chance of this, stated with the estimate: 65%); the middle value lies beyond the limit too.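

Moving from 2-fluorophenyl to 4-fluorophenyl on the carbonyl carbon of the second core gives an at least 1.8-fold higher number from compound 3 to compound 4 (0.26 log units; that floor lies within the scatter) in this assay. The result for compound 4 is a limit of the assay and not a number, which fits the change carrying over in the same direction but does not by itself establish a real rise on this core. The size of the change on the two cores cannot be compared: the same change on two cores in this assay, an at least 2.6-fold higher number (0.41 log units; beyond the scatter) from compound 1 to compound 2 and an at least 1.8-fold higher number (0.26 log units; that floor lies within the scatter) from compound 3 to compound 4; the limit leaves it open whether they differ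

Going by these compounds, how far compound 2 and compound 4 lie past the limit remains open. Also open, on these data alone, is whether a plain phenyl, or a methoxy or chloro group in place of the fluorine, would behave the same way on both cores.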